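Urea pair: trifluoromethyl against chloro on the terminal ring

The source may hold more compounds than are shown below. What is called first, only, known or untested is meant among the compounds shown, and "the series" means these compounds.

Two members of this series have been measured. Going by the values given here, compound 1 `COc1cc(Cl)cc(-c2nn(-c3cccc(NC(=O)c4ccc(Cl)c(Cl)c4)c3)cc2-c2ccncc2)c1` gives 75.4% in a functional assay on UACC-62 cells (Homo sapiens) for inhibition, read by sulforhodamine B assay, with a stated time of 48 h, tested at 10 uM (a higher number here means a weaker effect of the compound at the concentration tested, a lower number a stronger effect), while compound 2 `COc1cc(Cl)cc(-c2nn(-c3cccc(NC(=O)Nc4ccc(Cl)c(C(F)(F)F)c4)c3)cc2-c2ccncc2)c1` gives 6.62%, the lower of the two numbers; the only measured step, a number 68.8 percentage points lower from compound 1 to compound 2 (beyond the scatter), alters both the carbonyl linkage and the terminal ring. Compound 3 `COc1cc(Cl)cc(-c2nn(-c3cccc(NC(=O)Nc4ccc(Cl)c(Cl)c4)c3)cc2-c2ccncc2)c1` differs from compound 2 by chloro in place of trifluoromethyl on an aromatic carbon. Among the compounds with values here, no measured step isolates that exchange, so only a small shift is expected; the estimated step is a number 8.4 percentage points higher from compound 2 to compound 3 (within the scatter). Compound 3 is expected to give about 15%, within 3% to 45%.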

Compound 3, a percentage reported as activity, at one concentration (the size of the read-out at that concentration, not a potency): 4.38%
For compound 3 the middle estimate is 10.6 percentage points above the measured one; the range from low to high includes it.
By their numbers in this assay, from the lowest: compounds 3 and 2 (each within the scatter of the next); then compound 1.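

In this assay, trifluoromethyl and chloro cannot be told apart at this position, with a number 2.2 percentage points lower from compound 2 to compound 3 (within the scatter). With the 3,4-dichlorophenyl ring held constant, the large gain now belongs to the amino group on the carbonyl carbon alone, with a number 71 percentage points lower from compound 1 to compound 3 (beyond the scatter). No available evidence bears on the reason for either result. Going by these compounds, whether a nitrile or a methoxy group at this position would also match chloro remains open, as does the outcome of placing a methyl group on the urea nitrogen.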